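The source may hold more compounds than are shown below. What is called first, only, known or untested is meant among the compounds shown, and "the series" means these compounds.

Within the data shown here, compound 1 `CS(=O)(=O)c1ccc(Cc2n[nH]c(=S)n2/N=C/c2ccc(Cl)cc2)cc1` gives 47.5% in a functional assay on HeLa cells (Homo sapiens) for cytotoxicity, read by MTT assay, with a stated time of 48 h, tested at 25 uM (on this read-out higher numbers stand for a stronger effect at the one concentration tested and lower numbers for a weaker effect), the second highest of the three numbers measured so far. Compound 2 `CS(=O)(=O)c1ccc(Cc2n[nH]c(=S)n2/N=C/c2c(F)cccc2Cl)cc1` gives 55.3%, and compound 3 `CS(=O)(=O)c1ccc(Cc2n[nH]c(=S)n2/N=C/c2cccs2)cc1` gives 33.3%. The step of a number 7.8 percentage points higher from compound 1 to compound 2 (within the scatter) stays within the scatter, while the step of a number 14.2 percentage points lower from compound 1 to compound 3 (beyond the scatter) lies beyond it. Compound 4 `CS(=O)(=O)c1ccc(Cc2n[nH]c(=S)n2/N=C/c2ccc(-c3ccccc3)cc2)cc1` differs from compound 1 by phenyl in place of chloro on an aromatic carbon. Neither measured step bears closely on this change: each of them swaps the whole ring attached to the carbon with a double bond to nitrogen, whereas here only chloro gives way to phenyl on that ring, so no step beyond the scatter is expected. The estimate for compound 4 is 48%, with a range from 30% to 66%, which means an expected step of a number 0.5 percentage points higher from compound 1 to compound 4 (within the scatter).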

Compound 4, a percentage reported as activity, at one concentration (the size of the read-out at that concentration, not a potency): 37.3%
Compound 4: middle estimate off by 10.7 percentage points, on the high side; low and high end bracket the measured number.
By their numbers in this assay, from the lowest: compounds 3 and 4 (each within the scatter of the next); then compounds 1 and 2 (each within the scatter of the next).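

Putting phenyl in place of chloro, para to a large group, keeps the ring on the carbon with a double bond to nitrogen and alters only what it carries, and this gives a number 10.2 percentage points lower from compound 1 to compound 4 (beyond the scatter) as the result. So this position responds to a change of its substituent alone, and here the larger group, with six heavy atoms against one, lowers the number. Nothing at hand explains this step.

On these data alone, whether an amine, a methoxy group or a carboxylic acid at this position would keep the number of compound 1 or lower it remains open.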